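Swapping Bromine for Chlorine on a Fused Ring

A few compounds are considered here, and "the series" means these few. Any claim that something is new, unique, unknown or untested is made for them only; others in the source may bear on it.

Of the compounds shown here, three have been measured in a functional assay on cells (Cancer cell lines, Homo sapiens) for cytotoxicity, read by sulforhodamine B assay, with a stated time of 48 h; a lower number here means a stronger inhibitor of growth, a higher number a weaker inhibitor of growth. Compound 1 `COc1ccc(C2=NN(C3=NC(=O)/C(=C4\C(=O)Nc5ccc(Br)cc54)S3)C(c3ccc(Cl)cc3)C2)cc1` gives 7440 nM, compound 2 `O=C1N=C(N2N=C(c3ccc4ccccc4c3)CC2c2ccc(Cl)cc2)S/C1=C1/C(=O)Nc2ccccc21` gives 70300 nM, and compound 3 `COc1ccc(-c2cc(-c3ccc(Cl)cc3)n(C3C(=O)Nc4ccc(Br)cc43)n2)cc1` gives 36300 nM. Among these three numbers compound 3 stands second highest: its number sits close to that of compound 2, within the usual scatter, while compound 1 gives a number well below it, beyond the scatter. Compound 4 `COc1ccc(-c2cc(-c3ccc(Cl)cc3)n(C3C(=O)Nc4ccc(Cl)cc43)n2)cc1` differs from compound 3 in one place only: chloro in place of bromo on an aromatic carbon. Within the data shown here, no pair of measured compounds shows what such a swap does here, so the expected step is small and within the scatter, in no firm direction; the step this estimate means is a 1.1-fold higher number from compound 3 to compound 4 (0.04 log units; within the scatter). Compound 4 is therefore expected near 40000 nM, with a range from 15000 nM to 100000 nM.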

Compound 4, concentration for total growth inhibition: 28600 nM
Beside the measured number, compound 4's estimate is 1.4-fold (0.15 log units) above it; the measured number falls inside the stated range.
By their numbers in this assay, from the lowest: compound 1; then compounds 4, 3 and 2 (each within the scatter of the next, the first and the last beyond it).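

In this assay, among these compounds, chloro in place of bromo on this aromatic carbon of the fused system of two rings gives a 1.3-fold lower number from compound 3 to compound 4 (0.10 log units; within the scatter) and is the first direct reading of this swap. At this position, on this core, the two groups cannot be told apart. Nothing available explains this result.

From the compounds shown here alone, it remains open whether a clearly different group here, such as an amine or a carboxylic acid, would shift the number beyond the scatter. Also open, going by these compounds, is whether the same swap on the core of compound 1 would give a similarly small step.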